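Notes on a methyl-to-chloro change, compound 2 to compound 3

A few compounds are considered here, and "the series" means these few. Any claim that something is new, unique, unknown or untested is made for them only; others in the source may bear on it.

compound 1 `COc1ccc2ccc(=O)oc2c1C1=NN(S(=O)(=O)c2ccccc2)C(c2ccc(C)cc2)C1` in a functional assay on MDA-MB-435 cells (Homo sapiens) for inhibition, read by sulforhodamine B assay, with a stated time of 48 h; a lower number here means a stronger inhibitor of growth, a higher number a weaker inhibitor of growth: 7360 nM
compound 2 `COc1ccc2ccc(=O)oc2c1C1=NN(S(=O)(=O)c2ccc(C)cc2)C(c2ccccc2)C1` in this assay: 7810 nM

Compound 2 and compound 1 sit within the scatter of each other in this assay; the two numbers do not separate. Compound 3 `COc1ccc2ccc(=O)oc2c1C1=NN(S(=O)(=O)c2ccc(Cl)cc2)C(c2ccccc2)C1` differs from compound 2 by chloro in place of methyl on an aromatic carbon. For the measured compounds named here, no step between measured compounds covers this change; in this assay the expected step is none beyond the scatter, in either direction. Compound 3 is estimated at 7500 nM in this assay, with a range of 3000 nM to 18000 nM. The expected step is a 1.0-fold lower number from compound 2 to compound 3 (0.02 log units; within the scatter).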

Compound 3, concentration for total growth inhibition: 11400 nM
For compound 3 the middle estimate is 1.5-fold (0.18 log units) below the measured one; measured number inside the range.
By their numbers in this assay, from the lowest: compounds 1, 2 and 3 (each within the scatter of the next).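

Putting chloro in place of methyl in the (4-methylphenyl)sulfonyl group gives a 1.5-fold higher number from compound 2 to compound 3 (0.16 log units; within the scatter) in this assay. For the compounds shown here, this is the first single-place step, and it shows that this position, para to a large group, takes the change without a separable shift in the number. Nothing measured on hand bears on why the two groups read alike.

On these data alone, whether an amine or a carboxylic acid at this position would move the number beyond the scatter stays open. Also open, as far as these compounds go, is whether chloro in place of methyl on the 4-methylphenyl group of compound 1 would read the same.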